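Naphthalen-2-yl to Benzodioxinyl: Effect on Cytotoxicity

The compounds below may be only part of what the source reports. "The series", "measured", "known", "first", "only" and "open" are said of these compounds alone.

Of the compounds shown here, three with a shared core have been measured. Compound 1 `CC(C)N(Cc1cccc(OCCCCCC(=O)O)c1)C(=O)c1ccc(-c2cccc(Oc3ccccc3)c2)cc1` carries a phenoxy group on an aromatic carbon. In an ADME assay on BJ cells (Homo sapiens) for cytotoxicity, read by CellTiter-Glo and resazurin assay, with a stated time of 72 h (on this read-out lower numbers stand for an effect already at smaller amounts and higher numbers for an effect only at larger amounts of compound), compound 1 gives > 18700 nM, which is a limit of the assay rather than a number. Compound 2 `Cc1nnc(-c2cccc(-c3ccc(C(=O)N(Cc4cccc(OCCCCCC(=O)O)c4)C(C)C)cc3)c2)o1` carries a 5-methyl-1,3,4-oxadiazol-2-yl group in its place. In this assay compound 2 gives > 26000 nM, again a limit. Among the compounds with values here, the one measured step, a step that the two limits leave unreadable from compound 1 to compound 2, therefore cannot be read. Compound 3 `CCOC(=O)CCCCCOc1cccc(CN(C(=O)c2ccc(-c3ccc4ccccc4c3)cc2)C(C)C)c1` carries a naphthalen-2-yl group and is the starting point here. In this assay compound 3 gives > 26000 nM, once more a limit. All three values thus sit at limits: the limit of > 18700 nM in this assay, at which 1 of the 3 values shown sits, and (the limit of > 26000 nM in this assay, at which 2 of the 3 values shown sit).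

Compound 4 `CCOC(=O)CCCCCOc1cccc(CN(C(=O)c2ccc(-c3ccc4c(c3)OCCO4)cc2)C(C)C)c1` differs from compound 3 by 2,3-dihydro-1,4-benzodioxin-6-yl in place of naphthalen-2-yl on an aromatic carbon. Within the data shown here, no measured step bears on this change, and the single step available is unreadable. With nothing pointing to a shift, the step of a number no higher from compound 3 to compound 4 (the limit leaves the size open) is expected to stay within the scatter. Compound 4 is accordingly estimated at 26000 nM, with a range from 13000 nM to 52000 nM, and is expected most likely to be reported only as a limit.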

Compound 4, half-maximal effective concentration: > 24400 nM
Compound 4: a limit, no number; the forecaster's own chance of this, stated with the estimate: 85%; the middle value is on the limit's open side.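

Compound 3 and compound 4 both give only a limit in this assay, not a number, so the step between them cannot be read. The compounds shown leave open whether this ring change alters cytotoxicity, and at what concentration any of the four compounds would reach a half-maximal effect.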